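Moving a methyl group and its effect on cell toxicity

The compounds below may be only part of what the source reports. "The series", "measured", "known", "first", "only" and "open" are said of these compounds alone.

Compound 1 `Cc1ccccc1-n1cc(-c2ccccc2NS(=O)(=O)c2c[nH]c(=O)[nH]c2=O)nn1`: 56600 nM
Compound 2 `Cc1cccc(-n2cc(-c3ccccc3NS(=O)(=O)c3c[nH]c(=O)[nH]c3=O)nn2)c1`: 21900 nM
Compound 3 `Cc1ccccc1-n1cc(-c2cccc(NS(=O)(=O)c3c[nH]c(=O)[nH]c3=O)c2)nn1`: 15300 nM

These three compounds were tested in an ADME assay on L02 cells (Homo sapiens) for cytotoxicity, read by MTT assay, with a stated time of 24 h; on this read-out lower numbers stand for higher toxicity in this test and higher numbers for lower toxicity in this test. The difference between the core of compound 1 and the core of compound 3 is not broken down here. Compound 2 arises from compound 1 by 3-methylphenyl in place of 2-methylphenyl on an aromatic nitrogen, and this produced a 2.6-fold lower number from compound 1 to compound 2 (0.41 log units; beyond the scatter). Compound 4 `Cc1cccc(-n2cc(-c3cccc(NS(=O)(=O)c4c[nH]c(=O)[nH]c4=O)c3)nn2)c1` has not yet been measured; it arises from compound 3 by the same change, (3-methylphenyl in place of 2-methylphenyl on an aromatic nitrogen). For the measured compounds named here, a step of a similar size and direction is expected here, because the only precedent, a 2.6-fold lower number from compound 1 to compound 2 (0.41 log units; beyond the scatter), went that way, although a single precedent gives limited confidence. Compound 4 is therefore estimated at 7000 nM in this assay. That estimate corresponds to a 2.2-fold lower number from compound 3 to compound 4 (0.34 log units; beyond the scatter). The expected range for compound 4 runs from 3000 nM to 16000 nM.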

Compound 4, half-maximal cytotoxic concentration: 28300 nM
For compound 4 the middle estimate is 4.0-fold (0.61 log units) below the measured one; the whole stated range lies below it.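

In this assay putting 3-methylphenyl in place of 2-methylphenyl on the aromatic nitrogen gives a 1.8-fold higher number from compound 3 to compound 4 (0.27 log units; within the scatter) and so does not repeat the step seen on the core of compound 1. The two steps do not agree: the same change on two cores in this assay, a 2.6-fold lower number (0.41 log units; beyond the scatter) from compound 1 to compound 2 and a 1.8-fold higher number (0.27 log units; within the scatter) from compound 3 to compound 4, 4.8-fold (0.68 log units) apart, beyond the scatter of two such steps. For the compounds shown here, this shows that the outcome of this change did not carry from one core to the other, but with only one pair on each core it does not show what lies behind the difference or how a further core would respond.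

The compounds shown leave open how the change behaves on other cores. They also leave open whether a methoxy group or a chlorine atom in place of the methyl would give similar steps in this assay on either core.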